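Isopropylcarbonyl in Place of Isopropoxy: an Expected Outcome

A few compounds are considered here, and "the series" means these few. Any claim that something is new, unique, unknown or untested is made for them only; others in the source may bear on it.

For the measured compounds named here, compound 2 `Cc1c(F)c(Oc2cccc(OC(C)C)c2)nc(Oc2cccc(C(=N)N)c2)c1F` is one of two compounds measured so far. Going by the values given here, in an assay on isolated protein for inhibition of serine protease 1 (Bos taurus) (a higher number here means a weaker inhibitor, a lower number a stronger inhibitor), compound 2 gives 2900 nM, the only plain number among the values shown. Compound 1 `Cc1c(F)c(Oc2cccc(N)c2)nc(Oc2cccc(C(=N)N)c2)c1F` carries an amino group where compound 2 carries isopropoxy. For compound 1 this assay reports only a limit, > 5000 nM. The step of an at least 1.7-fold lower number from compound 1 to compound 2 (0.23 log units; that floor lies within the scatter) has a floor that lies within the scatter, and its true size is not known because one of the two values sits at the limit of > 5000 nM in this assay, at which 1 of the 2 values shown sits.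

Compound 3 `Cc1c(F)c(Oc2cccc(C(=N)N)c2)nc(Oc2cccc(C(=O)C(C)C)c2)c1F` has not yet been measured. It differs from compound 2 by isopropylcarbonyl in place of isopropoxy on an aromatic carbon. Among the compounds with values here, no measured step exchanges an ether for a carbonyl group, so the single step from amino to isopropoxy gives no guide to the size or direction of this change. Compound 3 is therefore expected to give about 2900 nM, within 800 nM to 10000 nM. This estimate means no change at the digits printed from compound 2 to compound 3 (within the scatter), a step expected to stay within the scatter.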

Compound 3, inhibition constant: 3800 nM
Compound 3: middle estimate off by 1.3-fold (0.12 log units), on the low side, within the range that was stated.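

In this assay, for the compounds shown here, the step of a 1.3-fold higher number from compound 2 to compound 3 (0.12 log units; within the scatter) gives the first comparison between two plain numbers at this position. It shows that isopropylcarbonyl can stand in place of isopropoxy on this aromatic carbon with no change beyond the scatter, so for this pair, the carbonyl and the ether read alike. The step of an at least 1.3-fold lower number from compound 1 to compound 3 (0.11 log units; that floor lies within the scatter) adds little, as it gives only a floor and its true size is not known: the limit of > 5000 nM in this assay, at which 1 of the 3 values shown sits.

No group shown at this position yet moves the number by a readable step beyond the scatter, so it remains open whether this position can affect the number at all. Going by these compounds, how a carboxylic acid, a primary amide or a longer alkyl chain on this aromatic carbon would read in this assay also remains open.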